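Aryl swap on the cyclopropane amide in the GPR88 series

The source may hold more compounds than are shown below. What is called first, only, known or untested is meant among the compounds shown, and "the series" means these compounds.

Measured so far:
compound 1 `CC(C)C[C@@H](N)CN(C(=O)[C@@H]1C[C@H]1c1ccccc1)c1ccc(-c2ccccc2)cc1` — 1.8 nM
compound 2 `N[C@@H](CC1CCCCC1)CN(C(=O)[C@@H]1C[C@H]1c1ccccc1)c1ccc(-c2ccccc2)cc1` — 1.7 nM
compound 3 `CC[C@H](C)[C@H](N)CN(C(=O)[C@@H]1C[C@H]1c1cccc(Cl)c1)c1ccc(-c2ccccc2)cc1` — 2200 nM

All numbers come from a functional assay for agonist activity at G protein-coupled receptor 88 (Homo sapiens), read by HTRF and cAMP accumulation; on this read-out higher numbers stand for an effect only at larger amounts of compound and lower numbers for an effect already at smaller amounts. Going by the values given here, compound 1 and compound 2 give numbers within the scatter of each other; the single measured step, a 1.1-fold lower number from compound 1 to compound 2 (0.02 log units; within the scatter), concerns the amino-bearing chain only and is within the scatter. Compound 3 gives the highest number of the three, and its gap to compound 1 and to compound 2 is beyond the scatter. Compound 3 differs from compound 1 and compound 2 in more than one place, so no single step accounts for that gap.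

Compound 4 `CC[C@H](C)[C@H](N)CN(C(=O)[C@@H]1C[C@H]1c1ccc(F)cc1F)c1ccc(-c2ccccc2)cc1` is the next member. It keeps the chain and the shared core of compound 3 and carries 2,4-difluorophenyl in place of 3-chlorophenyl on a saturated ring carbon. Among the compounds with values here, no measured step touches the aryl group on the three-membered ring; the one step available, a 1.1-fold lower number from compound 1 to compound 2 (0.02 log units; within the scatter), lies elsewhere and gives no guidance on this change. The estimate therefore rests on compound 3 alone, with a wide range to allow for a change in either direction. For compound 4 the expected result in this assay is 1500 nM, with a range from 250 nM to 9000 nM, which means an expected step of a 1.5-fold lower number from compound 3 to compound 4 (0.17 log units; within the scatter).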

Compound 4, half-maximal effective concentration: 1300 nM
The estimate for compound 4 lay 1.2-fold (0.06 log units) above the measured number; the measured number falls inside the stated range.
By their numbers in this assay, from the lowest: compounds 2 and 1 (each within the scatter of the next); then compounds 4 and 3 (each within the scatter of the next).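

In this assay the first step read on the aryl group at this saturated ring carbon of the three-membered ring is a 1.7-fold lower number from compound 3 to compound 4 (0.23 log units; within the scatter) and it shows that, with the chain of compound 3 held fixed, 3-chlorophenyl and 2,4-difluorophenyl cannot be told apart. Neither group carries a hydrogen-bond donor, a hydrogen-bond acceptor or a net charge, and this exchange of chlorine for two fluorines leaves the number of compound 4 within the scatter of the number of compound 3, so this one change does not recover or further lose activity on this read-out. No measurement on hand offers an explanation for why the two aryl groups read alike.

The gap between compound 3 and compounds 1 and 2 still cannot be divided between the amino-bearing chain and the aryl group, since the plain phenyl group paired with the chain of compound 3 does not appear among the compounds shown. Also open, from the compounds shown here alone, is how a methoxy group or a nitrile on the aryl group would read at this place, and whether either would behave differently from the halogens with this chain.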